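Swapping the aryl group on a thiazolidinone cytotoxicity series

A few compounds are considered here, and "the series" means these few. Any claim that something is new, unique, unknown or untested is made for them only; others in the source may bear on it.

Of the compounds shown here, two with a shared core have been tested in an ADME assay on Vero cells (Chlorocebus sabaeus) for cytotoxicity, read by neutral red uptake, tested at 394 ug/mL; on this read-out lower numbers stand for a stronger effect and higher numbers for a weaker effect at the one concentration tested. Compound 1 `COc1ccc(C2SCC(=O)N2CCN2CCCCC2)cc1` gives 73% in this assay. Compound 2 `O=C1CSC(c2cccc(Cl)c2)N1CCN1CCCCC1` gives 45% in this assay, the lowest of the two numbers, and the nearest neighbour, compound 1, stands higher by a gap beyond the usual scatter. Compound 3 `Cc1ccc(C2SCC(=O)N2CCN2CCCCC2)cc1` has not yet been measured. It differs from compound 2 in one place: 4-methylphenyl in place of 3-chlorophenyl on a saturated ring carbon. Compound 1 carries 4-methoxyphenyl at the same place and gives the higher number, so a move toward a weaker effect seems the more likely direction. For the measured compounds named here, still, no step between two measured compounds is known here, so the expected step from compound 2 to compound 3, a number 15 percentage points higher from compound 2 to compound 3 (beyond the scatter), is only a modest rise in this assay. Compound 3 is estimated to give 60% in this assay, within a range from 40% to 80%.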

Compound 3, a percentage reported as activity, at one concentration (the size of the read-out at that concentration, not a potency): 51%
For compound 3 the middle estimate is 9 percentage points above the measured one; low and high end bracket the measured number.
By their numbers in this assay, from the lowest: compounds 2 and 3 (each within the scatter of the next); then compound 1.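

In this assay, placing 4-methylphenyl where 3-chlorophenyl stood on the saturated ring carbon gives a step within the scatter (a number 6 percentage points higher from compound 2 to compound 3 (within the scatter)), so this aryl swap has no measurable effect on the number. By contrast, the smaller edit of methyl in place of methoxy on an aromatic carbon gives a clear step (a number 22 percentage points lower from compound 1 to compound 3 (beyond the scatter)), showing that a single substituent on this aryl group can shift the read-out, with compound 1 standing apart from the other two. Nothing measured here explains that shift.

Going by these compounds, it remains open whether the methoxy effect depends on where that group sits on the phenyl ring. A plain phenyl, or a phenyl carrying a hydroxyl or an amine, would help show whether the number follows the methoxy of compound 1 or the methyl of compound 3.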